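The source may report more compounds than this note shows. Statements on the series, on what has been measured and on what is new or still open speak of the compounds shown alone.

The study concerns a small group of compounds that share one core, and the question of how much of each is needed to act on cells. Compound 1 is `COc1cccc(OC)c1C(=O)Nc1c[nH]nc1C(=O)NC1CCC1`. In an ADME assay on MRC5 cells (Homo sapiens) for inhibition, with a stated time of 72 h (a lower number here means that less compound is needed, a higher number that more compound is needed for the effect), compound 1 gives > 50000 nM, which is a limit of the assay rather than a number. Compound 2, `COc1cccc(OC)c1C(=O)Nc1c[nH]nc1C(=O)NC1CCN(C(=O)OC(C)(C)C)CC1`, gives > 50000 nM, again a limit. Compound 3, `CO[C@H]1CC[C@H](NC(=O)c2n[nH]cc2NC(=O)C2CCOCC2)CC1`, gives > 50000 nM, also a limit. Within the data shown here, all three sit at the limit of > 50000 nM in this assay, at which 3 of the 3 values shown sit, so no measured compound in this group has yet produced a number, and there is no step between measured compounds from which a trend could be read.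

Compound 4 is `COc1cccc(OC)c1C(=O)Nc1c[nH]nc1C(=O)NC1CCC(C)CC1`. It differs from compound 1 in one place: 4-methylcyclohexyl in place of cyclobutyl on an amide-type nitrogen. Both the group that leaves and the group that enters are non-aromatic rings of carbon only, and nothing among the three measured compounds, all of which sit at the limit, points to this change moving the read-out in either direction. In this assay the expected step is a step that the limit leaves unreadable from compound 1 to compound 4, that is, nothing beyond the scatter. Compound 4 is therefore expected to give about 60000 nM, within a range from 20000 nM to 200000 nM, and most likely to be reported once more only as a limit.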

Compound 4, half-maximal effective concentration: 45000 nM
Estimate against measurement, compound 4: 1.3-fold (0.12 log units) above, and the stated range covers the measured number.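

Compound 4 is the only compound shown that gives a number rather than a limit, so this position on the amide-type nitrogen can carry 4-methylcyclohexyl and still yield a readable half-maximal effective concentration in this assay. As far as these compounds go, putting 4-methylcyclohexyl in place of cyclobutyl gives an at least 1.1-fold lower number from compound 1 to compound 4 (0.04 log units; that floor lies within the scatter), and as compound 1 has only a limit, this is a floor on the step, so the true size of the step stays unknown and what can be read does not show that the change did anything. The number for compound 4 also lies close to the ceiling that holds the rest of the group, so this single value does not yet open a trend: the limit of > 50000 nM in this assay, at which 3 of the 4 values shown sit.

The change alters the ring size and adds a methyl group at once, so the compounds shown cannot say which of the two matters, and a plain cyclohexyl would be needed to separate them. From the compounds shown here alone, it also remains open how this position would respond to quite different groups, such as a ring carrying a free amine or a carboxylic acid, or a longer open carbon chain.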